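Sulfonyl substituent and microsomal clearance in the alkyne acid series

A few compounds are considered here, and "the series" means these few. Any claim that something is new, unique, unknown or untested is made for them only; others in the source may bear on it.

Among the measured compounds shown here, compound 2 `Cc1ccc(S(C)(=O)=O)cc1C#Cc1cc(Cl)ccc1OCC(=O)O` is the only member of the series with a number in an in vitro ADME assay on microsomes from liver (Rattus norvegicus) for metabolic stability, read by LC-MS, tested at 1 uM; a lower number here means slower removal, a higher number faster removal of the compound: compound 2 gives 18 mL.min-1.g-1. Compound 1 `COCCNS(=O)(=O)c1ccc(C)c(C#Cc2cc(Cl)ccc2OCC(=O)O)c1` carries a (2-methoxyethyl)amino group on the sulfonyl sulfur in place of the methyl of compound 2. In this assay compound 1 returned only a limit, < 10 mL.min-1.g-1, so its true value is not known. The step of an at least 1.8-fold higher number from compound 1 to compound 2 (0.25 log units; that floor lies within the scatter) is therefore only a floor, and that floor lies within the scatter (the limit of < 10 mL.min-1.g-1 in this assay, at which 1 of the 2 values shown sits).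

Compound 3 `Cc1ccc(S(=O)(=O)N(C)C(C)C)cc1C#Cc1cc(Cl)ccc1OCC(=O)O` changes the same position again: isopropyl(methyl)amino in place of methyl on a sulfonyl sulfur. For the measured compounds named here, the one measured step that bears on this position runs the other way, from an amino group on the sulfonyl sulfur to methyl, and its size is uncertain. No step beyond the scatter is expected from compound 2 to compound 3; the estimate leans slightly to slower removal, a 1.2-fold lower number from compound 2 to compound 3 (0.08 log units; within the scatter). For compound 3 an intrinsic clearance of 15 mL.min-1.g-1 is expected, with a range from 6 mL.min-1.g-1 to 40 mL.min-1.g-1.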

Compound 3, intrinsic clearance in microsomes: 64 mL.min-1.g-1
Beside the measured number, compound 3's estimate is 4.3-fold (0.63 log units) below it; measured number above the stated range.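

In this assay, the position on the sulfonyl sulfur now shows a step beyond the scatter on a fully measured pair: a 3.6-fold higher number from compound 2 to compound 3 (0.55 log units; beyond the scatter). An amino group on the sulfonyl sulfur therefore does not by itself go with a low number, as the two amino compounds also stand apart, with an at least 6.4-fold higher number from compound 1 to compound 3 (0.80 log units; beyond the scatter), and compound 3 has the highest number of the three. That second step is only a floor, set by a limit: the limit of < 10 mL.min-1.g-1 in this assay, at which 1 of the 3 values shown sits.

Left open is where a methylamino, dimethylamino or morpholine group on the sulfonyl sulfur would fall, and so which part of the isopropyl(methyl)amino group goes with the higher number. From the compounds shown here alone, the true value of compound 1 also remains unknown, and with it the full size of its gap to compound 3.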